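The source may report more compounds than this note shows. Statements on the series, on what has been measured and on what is new or still open speak of the compounds shown alone.

Measured so far in a functional assay on MCF7 cells (Homo sapiens) for cytotoxicity, read by sulforhodamine B assay, with a stated time of 48 h; on this read-out lower numbers stand for stronger inhibition of growth and higher numbers for weaker inhibition of growth:

- compound 1, `Cc1ccc(-c2ccc(F)cc2)n1-c1ccc(-c2nc3ccccc3s2)cc1`: 2620 nM
- compound 2, `COc1ccc(-c2ccc(C)n2-c2ccc(-c3nc4ccccc4s3)cc2)cc1`: 2780 nM

For the measured compounds named here, compound 2 holds the higher of the two numbers, but its nearest neighbour is compound 1, and the single measured step, a 1.1-fold higher number from compound 1 to compound 2 (0.03 log units; within the scatter), lies within the scatter. On the numbers in hand, compound 1 and compound 2 cannot be told apart in this assay.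

Compound 3, `COc1ccc(-c2ccc(C)n2-c2ccc(-c3nc4ccc(OC)cc4s3)cc2)cc1`, has not yet been measured. It differs from compound 2 by methoxy in place of hydrogen on an aromatic carbon.

Going by the values given here, only one measured step exists, and it bears on this change loosely at best: it too introduced a methoxy, but at another place in the molecule, and it moved the number by no more than the scatter. Among the compounds with values here, no measured step shows what a methoxy in place of hydrogen does at the position of compound 3. With only compound 1 and compound 2 as a basis, nothing points to a step beyond the scatter in either direction, and the expectation for a 1.0-fold higher number from compound 2 to compound 3 (0.00 log units; within the scatter) is a change of about that size or none at all.

Compound 3 is therefore expected to give around 2800 nM in this assay, with a range from 1200 nM to 6500 nM.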

Compound 3, concentration for 50% growth inhibition: 3090 nM
The estimate for compound 3 lay 1.1-fold (0.04 log units) below the measured number; the measured number falls inside the stated range.
By their numbers in this assay, from the lowest: compounds 1, 2 and 3 (each within the scatter of the next).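

Working notes on the series: in this assay, methoxy in place of hydrogen on an aromatic carbon of the six-membered aromatic ring of carbon only, part of a fused system of two rings, gives a 1.1-fold higher number from compound 2 to compound 3 (0.05 log units; within the scatter), so compound 2 and compound 3 cannot be told apart. For the compounds shown here, this is the first reading at this position, meta to a fused ring and para to a fused ring; the earlier step, a 1.1-fold higher number from compound 1 to compound 2 (0.03 log units; within the scatter), concerned methoxy in place of fluoro at another place in the molecule. The position therefore accepts a methoxy without a step beyond the scatter on this read-out, and this holds for the background of compound 2, which already carries a methoxy elsewhere.

Still open, on these data alone, is whether a different group on this aromatic carbon, such as an amine, a carboxylic acid or a longer chain in place of methoxy, would give a step beyond the scatter in either direction. No measured evidence is available on what lies behind the result for compound 3.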